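The source may report more compounds than this note shows. Statements on the series, on what has been measured and on what is new or still open speak of the compounds shown alone.

Working notes on the series. Compound 2 `COc1ccc(/C=N/Nc2ncc3c(n2)n(C2CCCC2)c(=O)c(=O)n3C)cc1` gives 26300 nM in a functional assay on PC-3 cells (Homo sapiens) for antiproliferative activity, read by MTT assay (on this read-out higher numbers stand for weaker inhibition and lower numbers for stronger inhibition), the highest of the two numbers in hand; the nearest is compound 1 `Cn1c(=O)c(=O)n(C2CCCC2)c2nc(N/N=C/c3cccc(Cl)c3Cl)ncc21` at 17200 nM, and the step of a 1.5-fold higher number from compound 1 to compound 2 (0.18 log units; within the scatter) lies within the scatter. Compound 3 `Cn1c(=O)c(=O)n(C2CCCC2)c2nc(N/N=C/c3cccc(O)c3)ncc21` has not been measured. Its change from compound 2 is 3-hydroxyphenyl in place of 4-methoxyphenyl on a carbon with a double bond to nitrogen. Within the data shown here, the only step that bears on it, a 1.5-fold higher number from compound 1 to compound 2 (0.18 log units; within the scatter), swaps one aryl group for another with no shift beyond the scatter, so no step beyond the scatter is expected in this assay. Compound 3 is therefore estimated at 22000 nM (range 8000 nM to 60000 nM), an expected step of a 1.2-fold lower number from compound 2 to compound 3 (0.08 log units; within the scatter).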

Compound 3, half-maximal inhibitory concentration: 36300 nM
Estimate against measurement, compound 3: 1.7-fold (0.22 log units) below; low and high end bracket the measured number.
By their numbers in this assay, from the lowest: compounds 1, 2 and 3 (each within the scatter of the next, the first and the last beyond it).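

At the carbon with a double bond to nitrogen, 3-hydroxyphenyl in place of 4-methoxyphenyl gives a 1.4-fold higher number from compound 2 to compound 3 (0.14 log units; within the scatter) in this assay and so a hydrogen-bond donor entering here does not shift the number beyond the scatter. Among these compounds, in place of 2,3-dichlorophenyl the same group gives a 2.1-fold higher number from compound 1 to compound 3 (0.32 log units; beyond the scatter) as the first step at this position to pass the scatter, and it is modest. No evidence on hand accounts for this step.

Open, on these data alone, is whether an amine or a carboxylic acid on the phenyl ring, or a longer alkyl chain in place of the ring, would move the number further.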